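Ethylphenyl to Methyl on the Isoxazole-Bearing Nucleoside Core

The source may report more compounds than this note shows. Statements on the series, on what has been measured and on what is new or still open speak of the compounds shown alone.

Measured compounds:
compound 1, `CC(=O)OC[C@H]1O[C@@H](n2cc(-c3cc(-c4ccccc4)no3)c(=O)[nH]c2=O)C[C@@H]1OC(C)=O`: 91.4%
compound 2, `CCc1ccc(-c2cc(-c3cn([C@H]4C[C@H](OC(C)=O)[C@@H](COC(C)=O)O4)c(=O)[nH]c3=O)on2)cc1`: 92.7%

In a functional assay on NCI-H23 cells (Homo sapiens) for cytotoxicity, read by sulforhodamine B assay, tested at 10 uM (on this read-out lower numbers stand for less inhibition and higher numbers for more inhibition at the one concentration tested (going by the name of the read-out)), compound 2 gives 92.7%, the higher of the two numbers shown, while compound 1 gives 91.4%; the two lie within the scatter of each other, so no order between them can be read. Going by the values given here, the one measured step, a number 1.3 percentage points higher from compound 1 to compound 2 (within the scatter), concerns only the addition of ethyl to a phenyl ring that already stood on the core and says nothing about removing that ring.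

Compound 3, `CC(=O)OC[C@H]1O[C@@H](n2cc(-c3cc(C)no3)c(=O)[nH]c2=O)C[C@@H]1OC(C)=O`, differs from compound 2 by methyl in place of 4-ethylphenyl on an aromatic carbon. Among the compounds with values here, no measured step bears on this change; the loss of the whole 4-ethylphenyl ring is untested here. The estimate therefore carries a wide range: compound 3 is expected to give 65%, between 25% and 95%, meaning an expected step of a number 27.7 percentage points lower from compound 2 to compound 3 (beyond the scatter), most likely downward.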

Compound 3, a percentage reported as inhibition, at one concentration (the size of the read-out at that concentration, not a potency): 101%
The estimate for compound 3 lay 36 percentage points below the measured number; the whole stated range lies below it.
By their numbers in this assay, from the lowest: compounds 1, 2 and 3 (each within the scatter of the next).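

In this assay, the large aromatic group at this position of the five-membered ring can give way to methyl without a change that can be read: replacing 4-ethylphenyl with methyl gives a number 8.3 percentage points higher from compound 2 to compound 3 (within the scatter), and replacing phenyl with methyl gives a number 9.6 percentage points higher from compound 1 to compound 3 (within the scatter). The earlier pair showed only that adding ethyl to a phenyl ring left the read-out within the scatter, whereas these steps show the same for losing the whole ring. Nothing on hand explains this outcome.

Going by these compounds, the read-out comes from one concentration, so these numbers show only the size of the effect at that concentration; whether any of the three compounds would have a stronger or weaker effect at another concentration remains open. On these data alone, it also remains open how an amine, a carboxylic acid or a longer alkyl chain at this position would behave in place of methyl.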